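Extending the alkyl on the thiadiazole of compound 1

The source may report more compounds than this note shows. Statements on the series, on what has been measured and on what is new or still open speak of the compounds shown alone.

Measured compounds:
compound 1 `Cc1nnsc1CO/N=C/c1c(C)nn(C)c1Oc1ccccc1Cl` — > 50000 nM
compound 2 `Cc1nnsc1CO/N=C/c1c(C)nn(C)c1Oc1ccc(Br)cc1` — 11800 nM
compound 3 `Cc1ccc(Oc2c(/C=N/OCc3snnc3C)c(C)nn2C)cc1` — > 50000 nM

In a functional assay on Huh-7 cells (Homo sapiens) for inhibition, read by MTT assay, with a stated time of 48 h (on this read-out lower numbers stand for stronger inhibition and higher numbers for weaker inhibition), compound 1 gives only a limit, > 50000 nM. Compound 3 likewise gives only a limit in this assay, > 50000 nM. Within the data shown here, compound 2 is the one compound of the three with a measured number in this assay, 11800 nM. The measured steps all concern the phenyl attached through oxygen: an at least 4.2-fold lower number from compound 1 to compound 2 (0.62 log units; beyond the scatter), an at least 4.2-fold higher number from compound 2 to compound 3 (0.62 log units; beyond the scatter), while a step that the two limits leave unreadable from compound 1 to compound 3. Two of the three values sit at the same limit, (the limit of > 50000 nM in this assay, at which 2 of the 3 values shown sit).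

Compound 4 `CCCc1nnsc1CO/N=C/c1c(C)nn(C)c1Oc1ccccc1Cl` keeps the 2-chlorophenyl of compound 1 and differs from it at the other end: ethyl in place of hydrogen on a saturated chain carbon bound to an aromatic carbon. Among the measured compounds shown here, none of the measured steps touches this position, so nothing among them bears directly on the change. For the measured compounds named here, with compound 1 standing at a limit, and no step available at the thiadiazole side, the expectation is that compound 4 also sits near that limit, most likely again reported only as a limit in this assay. The step expected from compound 1 is a step that the limit leaves unreadable from compound 1 to compound 4. Compound 4 is estimated at 60000 nM, within a range of 15000 nM to 200000 nM.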

Compound 4, half-maximal inhibitory concentration: > 50000 nM
Compound 4: no number, only a limit; the forecaster's own chance of this, stated with the estimate: 70%; the middle value lies beyond the limit too.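

In this assay compound 4 gives > 50000 nM, which is a limit and not a number. Compound 1 is also only a limit, so no step can be read between compound 1 and compound 4. The compounds shown leave open whether 4-propyl-1,2,3-thiadiazol-5-yl in place of 4-methyl-1,2,3-thiadiazol-5-yl changes inhibition at all, as most values sit at one limit: the limit of > 50000 nM in this assay, at which 3 of the 4 values shown sit.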